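Sulfoxide to Sulfone at the Para Position: Expected Effect

The source may hold more compounds than are shown below. What is called first, only, known or untested is meant among the compounds shown, and "the series" means these compounds.

Measured so far in an assay on isolated protein for inhibition of RAC-alpha serine/threonine-protein kinase (Homo sapiens), tested at 30 uM; on this read-out higher numbers stand for more inhibition at the one concentration tested (going by the name of the read-out) and lower numbers for less inhibition:
Compound 1, `Cn1c(-c2ccccc2)nc2c(Sc3ccc(F)cc3)ncnc21`: 29%
Compound 2, `Cn1c(-c2ccc([S+](C)[O-])cc2)nc2c(Sc3ccc(F)cc3)ncnc21`: 10%

Within the data shown here, compound 2 stands lowest of the two numbers in this assay; its nearest neighbour is compound 1, and the only measured step, a number 19 percentage points lower from compound 1 to compound 2 (beyond the scatter), separates them. Compound 3, `Cn1c(-c2ccc(S(C)(=O)=O)cc2)nc2c(Sc3ccc(F)cc3)ncnc21`, has not yet been tested. It differs from compound 2 by a group of 4 heavy atoms (1 carbon, 2 oxygen, 1 sulfur; no ring) in place of a group of 3 heavy atoms (1 carbon, 1 oxygen, 1 sulfur; no ring), on an aromatic carbon. The step from compound 1 to compound 2 bears on this only loosely: it added the three-atom group to a bare hydrogen, whereas here one group of that kind is swapped for another of four heavy atoms at the same place. Among the measured compounds shown here, no measured pair shows that swap, so the expected change is none beyond the scatter. Compound 3 is therefore expected to sit close to compound 2, with an expected step of no change at the digits printed from compound 2 to compound 3 (within the scatter). The estimate for compound 3 is 10%, with a range from 0% to 25%.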

Compound 3, a percentage reported as inhibition, at one concentration (the size of the read-out at that concentration, not a potency): 4%
The estimate for compound 3 lay 6 percentage points above the measured number; measured number inside the range.
By their numbers in this assay, from the lowest: compounds 3 and 2 (each within the scatter of the next); then compound 1.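

In this assay, replacing the three-atom group with methylsulfonyl on this aromatic carbon gives a difference that cannot be told from the scatter (a number 6 percentage points lower from compound 2 to compound 3 (within the scatter)), so the second oxygen adds nothing readable at this place. Measured against the bare hydrogen, methylsulfonyl gives a number 25 percentage points lower from compound 1 to compound 3 (beyond the scatter), which means that both sulfur-bearing groups, para to a large group, now stand beyond the scatter on the same side of compound 1. No measured evidence bears on why the numbers fall this way.

The compounds shown leave open whether this drop belongs to sulfur-bearing groups or to any group at this place, since no amine, carboxylic acid or longer chain on that carbon is among them. They also leave open whether the same swap would read alike on a different core.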